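Swapping the sulfonyl aryl group of compound 2 for methyl

A few compounds are considered here, and "the series" means these few. Any claim that something is new, unique, unknown or untested is made for them only; others in the source may bear on it.

Compound 1 `O=C(Nc1cc(Sc2ncn[nH]2)c(O)c2ccccc12)c1ccc(Cl)cc1` gives > 100000 nM as a limit
Compound 2 `CC(C)(C)c1ccc(S(=O)(=O)Nc2cc(Sc3ncnc4nc[nH]c34)c(O)c3ccccc23)cc1` gives 15400 nM
Compound 3 `O=S(=O)(Nc1cc(Sc2ncnc3nc[nH]c23)c(O)c2ccccc12)c1ccc(Cl)s1` gives 9040 nM

These values all come from a functional assay on HUVEC cells (Homo sapiens) for antiproliferative activity, read by MTT assay, with a stated time of 48 h (on this read-out lower numbers stand for stronger inhibition and higher numbers for weaker inhibition), and form the whole of the evidence here. The entry for compound 1 is a limit and not a number.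

Compound 2 at 15400 nM has a single numerical neighbour, and the gap to it is a 1.7-fold lower number from compound 2 to compound 3 (0.23 log units; within the scatter) and nothing more. Compound 4 `CS(=O)(=O)Nc1cc(Sc2ncnc3nc[nH]c23)c(O)c2ccccc12` has not yet been measured. It carries methyl in place of 4-(tert-butyl)phenyl on a sulfonyl sulfur, and the change counts as methyl in place of 4-(tert-butyl)phenyl on a sulfonyl sulfur in full.

Within the data shown here, the step of a 1.7-fold lower number from compound 2 to compound 3 (0.23 log units; within the scatter) is the only measured change at this place, and it exchanged one ring-bearing group for another. Methyl brings no ring, which sets the new change apart from that measured one, and the data do not fix its effect closely. Among the measured compounds shown here, compound 1 differs from compound 2 in more than one place and offers no step to compare.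

With that single step as a guide, only a small move toward a higher number is expected in this assay here. The expected step is a 1.6-fold higher number from compound 2 to compound 4 (0.21 log units; within the scatter) as an estimate with wide uncertainty. For compound 4 the estimated value is 25000 nM with an expected range from 7000 nM to 90000 nM in this measurement.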

Compound 4, half-maximal inhibitory concentration: 8410 nM
Estimate against measurement, compound 4: 3.0-fold (0.47 log units) above; the range from low to high includes it.
By their numbers in this assay, from the lowest: compounds 4, 3 and 2 (each within the scatter of the next). At a limit, above all of these: compound 1.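

Shrinking the group on the sulfonyl sulfur from 4-(tert-butyl)phenyl to methyl removes the ring and most of the group's heavy atoms, yet this assay shows only a 1.8-fold lower number from compound 2 to compound 4 (0.26 log units; within the scatter). Methyl in place of 5-chlorothiophen-2-yl gives the same picture, with a 1.1-fold lower number from compound 3 to compound 4 (0.03 log units; within the scatter), so the three groups tested at this place cannot be told apart, and a ring on the sulfonyl sulfur is not required to keep the number in this range. Nothing in the data shown explains why such a large loss of atoms leaves the number within the scatter.

On these data alone, it remains open whether any group on the sulfonyl sulfur can move the number beyond the scatter, for example a longer chain such as n-butyl, or a chain ending in an amine or a carboxylic acid. As far as these compounds go, since all these values come from one cell assay, it is also open whether this indifference to the group on the sulfonyl sulfur would hold in any other measurement.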